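Swapping the N-Aryl Group in a Triazole Series

The source may hold more compounds than are shown below. What is called first, only, known or untested is meant among the compounds shown, and "the series" means these compounds.

Measured compounds:
compound 1, `CC(C)(C)OC(=O)N1CC=C(c2cn(-c3cccc(F)c3)nn2)CC1`: 39 nM
compound 2, `CC(C)(C)OC(=O)N1CC=C(c2cn(-c3ccc(F)cc3)nn2)CC1`: 31 nM

In a functional assay on CHO cells for antagonist activity at metabotropic glutamate receptor 1 (Mus musculus), read by FLIPR and calcium flux (on this read-out higher numbers stand for weaker inhibition and lower numbers for stronger inhibition), compound 1 gives 39 nM and compound 2 gives 31 nM. Within the data shown here, the one measured step, a 1.3-fold lower number from compound 1 to compound 2 (0.10 log units; within the scatter), lies within the scatter, so the two compounds cannot be ordered. Among the measured compounds shown here, compound 2 holds the lowest of the two numbers, with compound 1 as its only neighbour, within the scatter.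

Compound 3, `Cc1ccccc1-n1cc(C2=CCN(C(=O)OC(C)(C)C)CC2)nn1`, is not yet measured in this assay. It differs from compound 2 by 2-methylphenyl in place of 4-fluorophenyl on an aromatic nitrogen. For the measured compounds named here, the only measured step, a 1.3-fold lower number from compound 1 to compound 2 (0.10 log units; within the scatter), exchanged one fluorophenyl for another and bears only loosely on a change that brings in a methyl group in place of fluorine; no measured step covers this exchange. The expectation is therefore no step beyond the scatter, with wide uncertainty. Compound 3 is estimated at 60 nM, with a range of 15 nM to 300 nM, an expected step of a 1.9-fold higher number from compound 2 to compound 3 (0.29 log units; within the scatter).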

Compound 3, half-maximal inhibitory concentration: 58 nM
Compound 3: middle estimate off by 1.0-fold (0.01 log units), on the high side, and the stated range covers the measured number.
By their numbers in this assay, from the lowest: compounds 2, 1 and 3 (each within the scatter of the next).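

In this assay, the aryl group on the aromatic nitrogen proves open to a wider exchange than one fluorophenyl for another: 2-methylphenyl in place of 4-fluorophenyl gives a step that stays within the scatter (a 1.9-fold higher number from compound 2 to compound 3 (0.27 log units; within the scatter)). The same holds for 2-methylphenyl in place of 3-fluorophenyl (a 1.5-fold higher number from compound 1 to compound 3 (0.17 log units; within the scatter)), so all three aryl groups remain indistinguishable on this read-out, and none can be ranked above another. No available evidence explains this outcome or bears on it.

Because compound 3 changes both the substituent and its place on the phenyl ring, the compounds shown cannot separate those two changes; 2-fluorophenyl or 4-methylphenyl would be needed for that. On these data alone, it also remains open whether any group here moves the number beyond the scatter, such as a pyridine ring or a phenyl bearing an amine or a carboxylic acid.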